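The compounds below may be only part of what the source reports. "The series", "measured", "known", "first", "only" and "open" are said of these compounds alone.

Working notes on a small series tested in a functional assay on MDA-MB-231 cells (Homo sapiens) for inhibition, read by MTT assay, with a stated time of 48 h; a higher number here means a weaker inhibitor of growth, a lower number a stronger inhibitor of growth. Of the compounds shown here, three have numbers so far: compound 1 (`CC(C)(C)c1ccc(Nc2ncnc3ccc(NC(=S)NCc4ccccc4)cc23)cc1`) gives 8700 nM, compound 2 (`Fc1ccc(NC(=S)Nc2ccc3ncnc(Nc4cccc(Br)c4)c3c2)cc1Cl`) gives 300 nM and compound 3 (`FC(F)(F)c1cc(NC(=S)Nc2ccc3ncnc(Nc4cccc(Br)c4)c3c2)cc(C(F)(F)F)c1`) gives 800 nM. Compound 2 has the lowest of the three numbers, and its gaps to compound 3 and to compound 1 both lie beyond the scatter. For the measured compounds named here, no two measured compounds differ in one place only, so no single change has a measured size yet.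

The next compound is compound 4 (`S=C(Nc1cccnc1)Nc1ccc2ncnc(Nc3cccc(Br)c3)c2c1`). It keeps the rest of compound 2 but has pyridin-3-yl in place of 3-chloro-4-fluorophenyl on an amide-type nitrogen. Going by the values given here, the entering ring holds a hetero atom, and no measured compound offers a value for such a ring at this place.

Compound 2, at 300 nM, is the lowest point so far, and compound 3, with another substituted phenyl on that nitrogen, stands higher at 800 nM. Replacing the group of compound 2 is therefore expected to raise the number rather than lower it. A moderate weakening is expected in this assay, with an estimated step of a 4.0-fold higher number from compound 2 to compound 4 (0.60 log units; beyond the scatter), though this rests on very little data. For compound 4 the estimated value is 1200 nM, with an expected range of 350 nM to 4500 nM.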

Compound 4, concentration for 50% growth inhibition: > 30000 nM
Compound 4: only a limit was reported; the forecaster's own chance of this, stated with the estimate: 5%; middle value at least 25-fold (1.39 log units) from the limit.
By their numbers in this assay, from the lowest: compound 2; then compound 3; then compound 1. At a limit, above all of these: compound 4.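

In this assay compound 4 gives > 30000 nM, which is a limit of the assay and not a number. For the compounds shown here, this is the first single change with a measured size, and it shows that the group on the amide-type nitrogen whose other neighbour is the thiocarbonyl carbon can decide whether any growth inhibition is seen at all: pyridin-3-yl in place of 3-chloro-4-fluorophenyl gives an at least 100-fold higher number from compound 2 to compound 4 (2.00 log units; beyond the scatter), a large step with the rest of the molecule unchanged. The size of that step is a minimum and not a full measurement: the limit of > 30000 nM in this assay, at which 1 of the 4 values shown sits.

The change removes the chlorine and the fluorine and brings in a ring nitrogen in one move, so the compounds shown cannot tell which part carries the step; an unsubstituted phenyl at this place would separate the two, as would a pyridin-3-yl bearing chloro. Also open, on these data alone, is whether any ring with a hetero atom can be tolerated here, for example a pyrimidin-5-yl or a thiophen-3-yl, or whether a saturated ring such as cyclohexyl would hold the number near that of compound 2.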